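The compounds below may be only part of what the source reports. "The series", "measured", "known", "first", "only" and "open" are said of these compounds alone.

Notes on the series. Compound 1 `CN1CCN(c2ccc(Nc3ncc4c(n3)N(C3CCCC3)CC(=O)N4C)cc2)CC1` carries on an aromatic carbon a 4-methylpiperazin-1-yl group; in a functional assay on HeLa cells (Homo sapiens) for inhibition, read by MTT assay, with a stated time of 48 h (a lower number here means a stronger inhibitor, a higher number a weaker inhibitor), compound 1 gives 6750 nM. Compound 2 `CN1C(=O)CN(C2CCCC2)c2nc(Nc3ccc(N4CCCCC4)cc3)ncc21` has piperidin-1-yl in that place, and in this assay compound 2 gives 16900 nM, a step of a 2.5-fold higher number from compound 1 to compound 2 (0.40 log units; beyond the scatter). Compound 3 `CC1CCN(c2ccc(Nc3ncc4c(n3)N(C3CCCC3)CC(=O)N4C)cc2)CC1` carries 4-methylpiperidin-1-yl on the same aromatic carbon. In this assay compound 3 gives only a limit, > 30000 nM, so no number is known for it (the limit of > 30000 nM in this assay, at which 1 of the 3 values shown sits). The step is an at least 4.4-fold higher number from compound 1 to compound 3 (0.64 log units; beyond the scatter), and an at least 1.7-fold higher number from compound 2 to compound 3 (0.24 log units; that floor lies within the scatter). On the numbers shown compound 3 thus stands at the limit of this assay, with only a floor known for it.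

Compound 4 `CCN1C(=O)CN(C2CCCC2)c2nc(Nc3ccc(N4CCC(C)CC4)cc3)ncc21` differs from compound 3 by methyl in place of hydrogen on a saturated chain carbon bound to an amide-type nitrogen in a ring; read one bond further out, methyl becomes ethyl. None of the three measured steps touches this place: all three move the group on the aromatic carbon, and the amide-type nitrogen in a ring is left unchanged throughout. Going by the values given here, no measured step therefore bears on this change. The expected step is a step that the limit leaves unreadable from compound 3 to compound 4, none beyond the scatter in this assay. Compound 4 is expected to give 40000 nM, between 15000 nM and 100000 nM, most likely again reported only as a limit.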

Compound 4, half-maximal inhibitory concentration: > 30000 nM
Compound 4: no number, only a limit; the forecaster's own chance of this, stated with the estimate: 75%; the middle value lies beyond the limit too.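

In this assay compound 4 gives only a limit, > 30000 nM. With compound 3 also at a limit, no step can be read from compound 3 to compound 4: the limit of > 30000 nM in this assay, at which 2 of the 4 values shown sit.

The compounds shown leave open what numbers compound 3 and compound 4 truly have, and so whether methyl in place of hydrogen at this place changes the read-out at all.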